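The compounds below may be only part of what the source reports. "The series", "measured", "known", "first", "only" and "open" are said of these compounds alone.

In a functional assay on HT-29 cells (Homo sapiens) for antiproliferative activity (on this read-out lower numbers stand for stronger inhibition and higher numbers for weaker inhibition), compound 1 `CC1(C)CNC(=O)c2sc(Nc3ccc(I)cc3F)c(C(=O)NCCCO)c2C1` gives 6210 nM. Compound 2 `CC1(C)CNC(=O)c2sc(Nc3ccc(I)cc3F)c(C(=O)N[C@@H]3CCNC3)c2C1` gives 54 nM, and compound 3 `CC1(C)CNC(=O)c2sc(Nc3ccc(I)cc3F)c(C(=O)NC[C@H]3CCCN3)c2C1` gives 120 nM. Among these three numbers compound 3 stands second highest: its nearest neighbour is compound 2, as a 2.2-fold higher number from compound 2 to compound 3 (0.35 log units; beyond the scatter) shows, and its furthest is compound 1, as a 52-fold lower number from compound 1 to compound 3 (1.71 log units; beyond the scatter) shows.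

Compound 4 `CC1(C)CNC(=O)c2sc(Nc3ccc(I)cc3F)c(C(=O)NOCCO)c2C1` has not yet been measured. It differs from compound 3 in one place: 2-hydroxyethoxy in place of (pyrrolidin-2-yl)methyl on an amide-type nitrogen. The group that leaves carries one five-membered non-aromatic ring with one hetero atom and one defined stereocentre; the group that enters has no ring.

Among the measured compounds shown here, two measured steps bear on this change, both running the opposite way, from 3-hydroxypropyl or 2-hydroxyethyl toward pyrrolidin-3-yl or pyrrolidin-2-yl: a 120-fold lower number from compound 1 to compound 2 (2.06 log units; beyond the scatter) and a 52-fold lower number from compound 1 to compound 3 (1.71 log units; beyond the scatter). Compound 4 goes back from (pyrrolidin-2-yl)methyl to an open chain, 2-hydroxyethoxy, so a large rise in the number is expected, roughly undoing what is seen in compound 1 because a 52-fold lower number from compound 1 to compound 3 (1.71 log units; beyond the scatter) was large. Compound 4 is therefore estimated at 5000 nM, with a range from 1500 nM to 20000 nM. That estimate means a 42-fold higher number from compound 3 to compound 4 (1.62 log units; beyond the scatter), expected to lie well beyond the scatter.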

Compound 4, half-maximal inhibitory concentration: 340 nM
Compound 4: the middle estimate sits 15-fold (1.17 log units) above what was measured, and the stated range ends above it.
By their numbers in this assay, from the lowest: compound 2; then compound 3; then compound 4; then compound 1.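

In this assay, the step from the open-chain 3-hydroxypropyl amide to its 2-hydroxyethoxy counterpart is large (an 18-fold lower number from compound 1 to compound 4 (1.26 log units; beyond the scatter)), so a large part of the gain seen with the pyrrolidine-bearing compounds is also reached by a chain with no ring, and a change confined to two open chains on the amide-type nitrogen can move this read-out strongly. The pyrrolidine-bearing groups still give the lower numbers, but the gaps are only modest, both against (pyrrolidin-2-yl)methyl (a 2.8-fold higher number from compound 3 to compound 4 (0.45 log units; beyond the scatter)) and against pyrrolidin-3-yl (a 6.3-fold higher number from compound 2 to compound 4 (0.80 log units; beyond the scatter)), so a ring and its nitrogen are not needed at this position for much of the activity. Nothing measured here accounts for why the two open chains differ so widely.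

The compounds shown leave open whether the terminal hydroxyl of 2-hydroxyethoxy contributes, which a 2-methoxyethoxy or 2-aminoethoxy group on the same amide-type nitrogen would test. They also leave open how a longer chain, such as 3-hydroxypropoxy, would compare with 2-hydroxyethoxy.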